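The compounds below may be only part of what the source reports. "The series", "measured", "known", "first", "only" and "open" are said of these compounds alone.

In a functional assay on NCI-H2286 cells (Homo sapiens) for antiproliferative activity, read by CCK-8 assay, with a stated time of 72 h (on this read-out lower numbers stand for stronger inhibition and higher numbers for weaker inhibition), compound 1 `Cc1ccc(C(=O)Nc2cccc(C(F)(F)F)c2)cc1-c1ccc2c(-c3cnn(C4CC4)c3)n[nH]c2c1` gives 93 nM and compound 2 `Cc1ccc(C(=O)Nc2cccc(C(F)(F)F)c2)cc1-c1ccc2c(-c3cnn(C4CCOC4)c3)n[nH]c2c1` gives 69.7 nM, so the two stand level within the scatter. Compound 3 `Cc1ccc(C(=O)Nc2cccc(C(F)(F)F)c2)cc1-c1ccc2c(-c3cnn(C4CCN(C)CC4)c3)n[nH]c2c1` is still unmeasured. Its difference from compound 2 is 1-methylpiperidin-4-yl in place of oxolan-3-yl on an aromatic nitrogen, with 1-methylpiperidin-4-yl in place of oxolan-3-yl on an aromatic nitrogen. Among the compounds with values here, the only measured step on that nitrogen is a 1.3-fold lower number from compound 1 to compound 2 (0.13 log units; within the scatter). On this one step, no change beyond the scatter is expected in this assay, in either direction. The expected step is a 1.1-fold lower number from compound 2 to compound 3 (0.03 log units; within the scatter). Compound 3 is estimated at 65 nM, with an expected range of 22 nM to 200 nM.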

Compound 3, half-maximal inhibitory concentration: 56.5 nM
For compound 3 the middle estimate is 1.2-fold (0.06 log units) above the measured one; low and high end bracket the measured number.
By their numbers in this assay, from the lowest: compounds 3, 2 and 1 (each within the scatter of the next).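

On the aromatic nitrogen, 1-methylpiperidin-4-yl brings a ring nitrogen and a six-membered ring into the series, yet this assay shows a 1.2-fold lower number from compound 2 to compound 3 (0.09 log units; within the scatter) and a 1.6-fold lower number from compound 1 to compound 3 (0.22 log units; within the scatter). Cyclopropyl, oxolan-3-yl and 1-methylpiperidin-4-yl therefore cannot be told apart at this position, which extends the flat picture from two groups to three. Nothing available accounts for this flatness. On these data alone, whether a carboxylic acid, an open-chain amine or a longer alkyl chain on this nitrogen would move the number beyond the scatter remains open.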